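Pyridin-3-yl Hydrazone: Expected Paw Edema Inhibition

The source may hold more compounds than are shown below. What is called first, only, known or untested is meant among the compounds shown, and "the series" means these compounds.

Compound 3 `COc1ccc(/C=N/NC(=O)c2cccnc2Nc2cccc(C(F)(F)F)c2)c(OC)c1` stands lowest of the three compounds measured in a functional assay on the whole organism (strain Wistar) for inhibition, with Rattus norvegicus as the target, read by paw edema, with a stated time of 30 min, at a dose of 10 mg/kg by the intraperitoneal route (a lower number here means less inhibition, a higher number more inhibition at the dose given (going by the name of the read-out)), where compound 3 gives 37.8%; compound 1 `O=C(N/N=C/c1cccc(O)c1)c1cccnc1Nc1cccc(C(F)(F)F)c1` gives 67.5% and compound 2 `O=C(N/N=C/c1ccc(O)c(O)c1)c1cccnc1Nc1cccc(C(F)(F)F)c1` gives 51.4%. Compound 4 `O=C(N/N=C/c1cccnc1)c1cccnc1Nc1cccc(C(F)(F)F)c1` differs from compound 3 in one place: pyridin-3-yl in place of 2,4-dimethoxyphenyl on a carbon with a double bond to nitrogen. Among the measured compounds shown here, two measured steps bear on this carbon. The step of a number 29.7 percentage points lower from compound 1 to compound 3 (beyond the scatter) and the step of a number 13.6 percentage points lower from compound 2 to compound 3 (beyond the scatter) show that exchanging the aryl group there moved the read-out by modest amounts, each beyond the scatter, and both exchanges ended at compound 3, the lowest point. For the measured compounds named here, compound 4 carries neither the hydroxy groups of compound 1 and compound 2 nor the methoxy groups of compound 3, and no measured step shows what pyridin-3-yl does on that carbon. The expected step is a number 7.2 percentage points higher from compound 3 to compound 4 (within the scatter), which would not go beyond the scatter. Compound 4 is therefore estimated at 45%, with a range from 25% to 65%.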

Compound 4, a percentage reported as inhibition, in the whole organism at one dose (the size of the read-out at that dose, not a potency): 59.1%
The estimate for compound 4 lay 14.1 percentage points below the measured number; the measured number falls inside the stated range.
By their numbers in this assay, from the lowest: compound 3; then compounds 2, 4 and 1 (each within the scatter of the next, the first and the last beyond it).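

In this assay, pyridin-3-yl on the carbon with a double bond to nitrogen gives a number 21.3 percentage points higher from compound 3 to compound 4 (beyond the scatter) and so recovers much of what the 2,4-dimethoxyphenyl group had lost. The same exchange gives a number 7.7 percentage points higher from compound 2 to compound 4 (within the scatter) and a number 8.4 percentage points lower from compound 1 to compound 4 (within the scatter), both within the scatter, so a ring without hydroxy groups can match the hydroxylated aryl groups at this carbon. Nothing measured here explains these steps.

Still open, as far as these compounds go, is how a plain phenyl group would compare at this carbon. Also open, from the compounds shown here alone, is what an amine or a carboxylic acid on the ring would do.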